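The source may hold more compounds than are shown below. What is called first, only, known or untested is meant among the compounds shown, and "the series" means these compounds.

Three compounds measured in a functional assay on CCRF-CEM cells (Homo sapiens), with a stated time of 72 h (on this read-out higher numbers stand for weaker inhibition and lower numbers for stronger inhibition), give the background for this step. Compound 1, `Cc1ccc(NC(=S)N/N=C2\C(=O)Nc3ccc(Br)cc32)cc1`, gives 6800 nM. Compound 2, `O=C1/C(=N\NC(=S)Nc2ccc(Cl)cc2)c2cc(F)ccc2N1Cc1ccc(F)cc1`, gives 56000 nM. Compound 3, `Cc1ccc(CN2C(=O)/C(=N\NC(=S)Nc3ccc(Cl)cc3)c3cc(Cl)ccc32)cc1`, gives 18000 nM, which places compound 3 second highest of the three numbers: compound 1 stands at a lower number, beyond the usual scatter, and compound 2 stands at a higher number, also beyond the scatter.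

Compound 4 is `O=C1/C(=N\NC(=S)Nc2ccc(Cl)cc2)c2cc(Cl)ccc2N1Cc1ccc(F)cc1`, not yet measured. The change from compound 3 to compound 4 is fluoro in place of methyl on an aromatic carbon. The shared core and the remaining substituents stay the same; only fluoro in place of methyl on an aromatic carbon is altered. Going by the values given here, no measured pair shows this change alone, so the expected size of the step in this assay rests on the spread of the three numbers; a small step toward a weaker inhibition, within or just beyond the scatter, is expected.

Compound 4 is therefore estimated at 25000 nM, with a range from 9000 nM to 70000 nM, a step of a 1.4-fold higher number from compound 3 to compound 4 (0.14 log units; within the scatter).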

Compound 4, half-maximal inhibitory concentration: 50000 nM
The estimate for compound 4 lay 2.0-fold (0.30 log units) below the measured number; the range from low to high includes it.
By their numbers in this assay, from the lowest: compound 1; then compound 3; then compounds 4 and 2 (each within the scatter of the next).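

In this assay, the position on the benzyl ring proves sensitive: going from 4-methylbenzyl to 4-fluorobenzyl weakens inhibition, giving a 2.8-fold higher number from compound 3 to compound 4 (0.44 log units; beyond the scatter) and a real difference for a swap of one heavy atom. The other halogen site behaves differently, since chloro in place of fluoro on an aromatic carbon of the shared core gives a 1.1-fold lower number from compound 2 to compound 4 (0.05 log units; within the scatter), so compound 2 and compound 4 cannot be told apart in this read-out. Nothing at hand accounts for the contrast between these two changes.

On these data alone, each change rests on a single pair, so it remains open whether the methyl advantage holds with other groups elsewhere in the molecule. As far as these compounds go, how a methoxy group or an amine would read at the benzyl position also remains open.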